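The source may report more compounds than this note shows. Statements on the series, on what has been measured and on what is new or still open speak of the compounds shown alone.

Measured in a functional assay on Bel-7402 cells (Homo sapiens) for cytotoxicity, read by resazurin assay, with a stated time of 72 h; on this read-out higher numbers stand for weaker inhibition and lower numbers for stronger inhibition:

compound 1, `N#CCCSC(=S)NCc1cccnc1`, gives 1030 nM
compound 2, `Cc1nc(-c2ccccc2)oc1CNC(=S)SCCC#N`, gives 18000 nM
compound 3, `N#CCCSC(=S)NCc1nnc(-c2ccccc2)o1`, gives 25700 nM

Of these three, compound 1 stands lowest on this assay: compound 2 sits beyond the scatter at a clearly higher number, and compound 3 further still. The three compounds share the thiocarbamate chain and differ in the ring attached through the methylene, so none of them is separated from another by a single change.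

Compound 4, `OCCCSC(=S)NCc1cccnc1`, keeps the core of compound 1 and changes only the far end of the chain: hydroxymethyl in place of cyano on a saturated chain carbon, two bonds along the chain from a sulfur. Among the compounds with values here, no measured pair shows this exchange, so its effect on this assay cannot be read from the data. A step in either direction is possible; with nothing to point one way, a modest movement, not far beyond the scatter, is the expectation. Compound 4 is therefore estimated at 1600 nM, with a range from 400 nM to 6500 nM, which means an expected step of a 1.6-fold higher number from compound 1 to compound 4 (0.19 log units; within the scatter).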

Compound 4, half-maximal inhibitory concentration: 3650 nM
Estimate against measurement, compound 4: 2.3-fold (0.36 log units) below; the range from low to high includes it.
By their numbers in this assay, from the lowest: compound 1; then compound 4; then compounds 2 and 3 (each within the scatter of the next).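

Within the data shown here, the earlier compounds all carry the nitrile at the chain end, so this is the first reading of that position, and it shows that the position is not indifferent in this assay: hydroxymethyl in place of cyano gives a 3.5-fold higher number from compound 1 to compound 4 (0.55 log units; beyond the scatter), a modest step beyond the scatter. The exchange removes the triple bond and brings in a hydrogen-bond donor, while the heavy-atom count stays the same, so the step does not come with a change in that count. Nothing available here accounts for the direction or the size of this step.

The compounds shown leave open how an amine or a carboxylic acid at the far end of the chain, or a longer chain, would read. They also leave open whether the same exchange would move the number in the same way on the cores of compound 2 and compound 3.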